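From Dichlorophenyl to Difluorophenyl on the Carbonyl Carbon

The source may report more compounds than this note shows. Statements on the series, on what has been measured and on what is new or still open speak of the compounds shown alone.

Compound 1 `COc1cc(-c2cc(/C=C/C(=O)c3ccc(Cl)c(Cl)c3)[nH]n2)cc(OC)c1OC` gives only a limit in a functional assay on UO-31 cells (Homo sapiens) for inhibition, read by sulforhodamine B assay, with a stated time of 48 h (a higher number here means a weaker inhibitor of growth, a lower number a stronger inhibitor of growth), namely > 100000 nM, and so stands at the limit of > 100000 nM in this assay, at which 1 of the 2 values shown sits, with no number of its own. Compound 2 `COc1ccc(-c2cc(/C=C/C(=O)c3cc(OC)c(OC)c(OC)c3)[nH]n2)cc1OC` differs from compound 1 in several places. In this assay compound 2 gives 2590 nM. Compound 3 `COc1cc(-c2cc(/C=C/C(=O)c3ccc(F)c(F)c3)[nH]n2)cc(OC)c1OC` differs from compound 1 by 3,4-difluorophenyl in place of 3,4-dichlorophenyl on a carbonyl carbon. Among the measured compounds shown here, no measured pair shows the effect of this halogen exchange, so the step is expected to be small, within the scatter or at most modestly towards stronger inhibition. Compound 3 is therefore estimated at 80000 nM, within 20000 nM to 300000 nM, an expected step of an at least 1.2-fold lower number from compound 1 to compound 3 (0.09 log units; that floor lies within the scatter).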

Compound 3, concentration for total growth inhibition: 14200 nM
Beside the measured number, compound 3's estimate is 5.6-fold (0.75 log units) above it; the measured number lies below the stated range.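

In this assay, the halogens on the ring at this carbonyl carbon prove to matter: 3,4-difluorophenyl in place of 3,4-dichlorophenyl gives an at least 7.0-fold lower number from compound 1 to compound 3 (0.84 log units; beyond the scatter). Among the compounds shown here, this single exchange, with the heavy-atom count unchanged, brings a limit down to a measured number, which the earlier compounds did not show at this position. The step is only a floor, as compound 1 gives only a limit: the limit of > 100000 nM in this assay, at which 1 of the 3 values shown sits.

As far as these compounds go, it remains open how an unsubstituted phenyl, a phenyl bearing a single fluorine or a phenyl bearing a nitrile would read on this carbonyl carbon, with the rest of compound 3 unchanged.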